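Replacing the Carbamoyl Ring Substituent with Hydroxymethyl

The compounds below may be only part of what the source reports. "The series", "measured", "known", "first", "only" and "open" are said of these compounds alone.

Compound 1 `O=C(O)CC/C=C\CO[C@H]1[C@@H](OCc2ccc(-c3ccccc3)cc2)CC[C@@H]1N1CCCCC1` was tested in a functional assay for antagonist activity at thromboxane A2 receptor (Rattus norvegicus) (a higher number here means weaker binding, a lower number tighter binding), and gave 31.6 nM; 50.1 nM (2 entries); the spread between its repeated entries the several entries of compound 1 in this assay, 31.6 nM; 50.1 nM (2 entries) shows how far the same compound can move on retesting. Compound 2 `O=C(O)CC/C=C\CO[C@@H]1C(OCc2ccc(-c3ccccc3)cc2)CC[C@@H]1N1CCCCC1` differs from compound 1 only in how one carbon is drawn (the fact that one of compounds 1 and 2 is drawn with a defined configuration and the other without, at the place where they differ), and in this assay compound 2 gives 15.9 nM. Compound 3 `NC(=O)c1ccccc1-c1ccc(COC2CC[C@H](N3CCCCCC3)[C@H]2OC/C=C\CCC(=O)O)cc1` differs from both in more than one place; in this assay compound 3 gives 15.9 nM, level with compound 2 at the digits shown, a gap that lies within the scatter. All three measured compounds thus fall in a narrow band.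

Compound 4 `O=C(O)CC/C=C\CO[C@H]1C(OCc2ccc(-c3ccc(CO)cc3)cc2)CC[C@@H]1N1CCCCCC1` has not been measured. It differs from compound 3 in a single place: 4-(hydroxymethyl)phenyl in place of 2-carbamoylphenyl on an aromatic carbon, sitting on an aromatic carbon of a six-membered aromatic ring of carbon only, para to a large group. Within the data shown here, no measured pair among compounds 1 to 3 tests this kind of swap, so no measured step guides the expectation directly. The step expected here, a 1.3-fold higher number from compound 3 to compound 4 (0.10 log units; within the scatter), is small and not beyond the scatter of repeat measurements. Compound 4 is therefore expected to give about 20 nM, with a likely range from 7 nM to 60 nM.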

Compound 4, dissociation constant: 20 nM
The estimate for compound 4 equals the measured number at the digits printed; low and high end bracket the measured number.
By their numbers in this assay, from the lowest: compounds 2, 3 and 4 (each within the scatter of the next).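

In this assay, the swap to 4-(hydroxymethyl)phenyl in place of 2-carbamoylphenyl gives a 1.3-fold higher number from compound 3 to compound 4 (0.10 log units; within the scatter), so this place, on an aromatic carbon para to a large group, takes either group without a change that can be told from the noise. This is the only pair shown that differs in this one place, and the swap alters both the group and the number in its name, so it gives a direct reading here but cannot separate those two changes. A step of this size also has to be read against how far one compound can move on retesting: the several entries of compound 1 in this assay, 31.6 nM; 50.1 nM (2 entries)

From the compounds shown here alone, both groups have the same hydrogen-bond donor and acceptor counts and no net charge, so it remains open how a group with different counts or a charge, such as a carboxylic acid or a primary amine, would fare at this place. Also open, going by these compounds, is whether hydroxymethyl would give a similar reading on the core of compound 1, and whether any group here can move the number beyond the scatter.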